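A few compounds are considered here, and "the series" means these few. Any claim that something is new, unique, unknown or untested is made for them only; others in the source may bear on it.

Working notes on the series. In a functional assay on K562 cells (Homo sapiens) for inhibition, read by fluorescence, with a stated time of 72 h (a higher number here means a weaker inhibitor of growth, a lower number a stronger inhibitor of growth), compound 3 (`CC(C)CCn1cnc2c(Nc3cccc(Cl)c3)nc(N[C@H]3CC[C@H](N)CC3)nc21`) gives 1500 nM, compound 2 (`CCCCCCn1cnc2c(Nc3cccc(Cl)c3)nc(N[C@H]3CC[C@H](N)CC3)nc21`) gives 2300 nM and compound 1 (`COc1ccc(Cn2cnc3c(Nc4cccc(Cl)c4)nc(N[C@H]4CC[C@H](N)CC4)nc32)cc1`) gives 2800 nM. Compound 3 cannot be separated from either of the others: the data show a 1.5-fold lower number from compound 2 to compound 3 (0.19 log units; within the scatter) and a 1.9-fold lower number from compound 1 to compound 3 (0.27 log units; within the scatter). The remaining pair behaves alike, with a 1.2-fold lower number from compound 1 to compound 2 (0.09 log units; within the scatter).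

Among the compounds with values here, the next compound, compound 4 (`N[C@H]1CC[C@H](Nc2nc(Nc3cccc(Cl)c3)c3ncn(Cc4ccccc4)c3n2)CC1`), has no measurement yet. Its difference from compound 3 is phenyl in place of isobutyl on a saturated chain carbon bound to an aromatic nitrogen. In words, this is phenyl in place of isobutyl on a saturated chain carbon bound to an aromatic nitrogen, which also reads as isopentyl to benzyl.

The closest evidence is the swap at the same place that links 4-methoxyphenyl and isobutyl, a 1.9-fold lower number from compound 1 to compound 3 (0.27 log units; within the scatter). The pentyl swap, a 1.2-fold lower number from compound 1 to compound 2 (0.09 log units; within the scatter), also bears on it. Within the data shown here, no measured compound carries the plain phenyl, so its effect is inferred from these steps alone. All steps at this place stay within the scatter, so no step beyond the scatter is expected in this assay, and no direction can be firmly assigned. The expected move is a 1.3-fold higher number from compound 3 to compound 4 (0.12 log units; within the scatter).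

The estimate for compound 4 is 2000 nM, with an expected range of 1000 nM to 4000 nM.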

Compound 4, concentration for 50% growth inhibition: 3000 nM
Estimate against measurement, compound 4: 1.5-fold (0.18 log units) below; the range from low to high includes it.
By their numbers in this assay, from the lowest: compounds 3, 2, 1 and 4 (each within the scatter of the next).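

Benzyl at this place, on a saturated chain carbon bound to an aromatic nitrogen, gives the series its first unsubstituted aromatic ring there, and in this assay it does not separate from the branched or straight chains: the data show a 2.0-fold higher number from compound 3 to compound 4 (0.30 log units; within the scatter) and a 1.3-fold higher number from compound 2 to compound 4 (0.12 log units; within the scatter) as the steps from those two compounds. The methoxy group also gets its first direct reading, since hydrogen in its place on an aromatic carbon gives a 1.1-fold higher number from compound 1 to compound 4 (0.03 log units; within the scatter) and so leaves no effect of that group that can be told apart from the scatter. No supporting data bear on these results, so they stay a plain record of numbers and offer no explanation.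

The compounds shown leave open whether any group at this place can move the number beyond the scatter, as all four sit within it of one another and span only isopentyl, hexyl, benzyl and its methoxy-bearing form. A chain ending in an amine or a carboxylic acid, a much longer chain such as decyl, or a chlorine on the benzyl ring would test this, and the shared core stays unvaried here.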